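The compounds below may be only part of what the source reports. "The series", "measured", "known", "first", "only" and "open" are said of these compounds alone.

Measured so far, all in a physicochemical assay, read by spectrophotometry, with a stated time of 25 min; a lower number here means a stronger inhibitor, a higher number a weaker inhibitor:

Compound 1, `O=c1cc(-c2ccccc2)oc2cc(OCCCCNc3nc4ccccc4s3)cc(O)c12`: 26.5 ug/mL
Compound 2, `O=c1cc(-c2ccccc2)oc2cc(OCCCCNc3nc4ccc(Cl)cc4s3)cc(O)c12`: 13.2 ug/mL
Compound 3, `O=c1cc(-c2ccccc2)oc2cc(OCCCCNc3nc4c(F)cc(F)cc4s3)cc(O)c12`: 15.1 ug/mL

Compound 2 has the lowest of the three numbers in this assay, but its nearest neighbour is compound 3 at a 1.1-fold higher number from compound 2 to compound 3 (0.06 log units; within the scatter), and even its furthest is compound 1 at a 2.0-fold lower number from compound 1 to compound 2 (0.30 log units; within the scatter), so all three sit within the scatter of one another and none can be called the stronger inhibitor.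

Compound 4, `O=c1cc(-c2ccccc2)oc2cc(OCCCCNc3nc4ccc(C(F)(F)F)cc4s3)cc(O)c12`, has not yet been measured. It differs from compound 2 in one place: trifluoromethyl in place of chloro on an aromatic carbon.

Going by the values given here, two measured steps bear on it, both changes on the same fused ring: a 2.0-fold lower number from compound 1 to compound 2 (0.30 log units; within the scatter) and a 1.8-fold lower number from compound 1 to compound 3 (0.24 log units; within the scatter). Each stays within the scatter, and the two substituted compounds match each other at a 1.1-fold higher number from compound 2 to compound 3 (0.06 log units; within the scatter). Swapping one group for another on that ring has therefore so far moved the number in this assay by no more than the usual repeat variation, and the same is expected here: a step of about a 1.1-fold lower number from compound 2 to compound 4 (0.02 log units; within the scatter), with no direction beyond the scatter.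

Compound 4 is thus estimated at 12.5 ug/mL in this assay, within a range from 6 ug/mL to 26 ug/mL.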

Compound 4, half-maximal inhibitory concentration: 16.3 ug/mL
Compound 4: the middle estimate sits 1.3-fold (0.12 log units) below what was measured; the range from low to high includes it.
By their numbers in this assay, from the lowest: compounds 2, 3, 4 and 1 (each within the scatter of the next).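

In this assay, exchanging the single chlorine atom of chloro for trifluoromethyl, with its 4 heavy atoms, on this aromatic carbon gives a 1.2-fold higher number from compound 2 to compound 4 (0.09 log units; within the scatter) and so stays within the scatter, which means that a group with more heavy atoms at this place is not told apart from chloro here. Set against the hydrogen of the unsubstituted compound, the same group gives a 1.6-fold lower number from compound 1 to compound 4 (0.21 log units; within the scatter) and also stays within the scatter, so neither trifluoromethyl here nor chloro in compound 2 can be said to differ from hydrogen at this place, and all four compounds now remain inside the usual repeat variation of this assay without any group standing apart. No measurement is available to explain why these groups read alike, and none bears on this result.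

The compounds shown leave open whether a different kind of group on this aromatic carbon, such as an amine, a carboxylic acid or a methoxy group, would move the number beyond the scatter. They also leave open what a longer chain on the amine nitrogen would do, as all four compounds carry the same chain.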